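The source may hold more compounds than are shown below. What is called first, only, known or untested is meant among the compounds shown, and "the series" means these compounds.

Measured compounds in an assay on isolated protein for inhibition of malate dehydrogenase, mitochondrial (Homo sapiens), with a stated time of 30 min; a higher number here means a weaker inhibitor, a lower number a stronger inhibitor: compound 1 `COCCOc1ccc(C(=O)OC)cc1NC(=O)COc1ccc(C(C)(C)CC(C)(C)C)cc1` gives 29000 nM; compound 2 `COC(=O)c1cccc(NC(=O)COc2ccc(C(C)(C)CC(C)(C)C)cc2)c1` gives 8920 nM; compound 3 `COC(=O)c1ccc(O)c(NC(=O)CCCOc2ccc(C(C)(C)CC(C)(C)C)cc2)c1` gives 1110 nM.

Compound 2 stands second highest of the three numbers in this assay. Within the data shown here, its nearest neighbour is compound 1, from which it is reached by the one measured step, a 3.3-fold lower number from compound 1 to compound 2 (0.51 log units; beyond the scatter). Among the measured compounds shown here, compound 3 sits furthest away with the lowest number of the set; compound 3 differs from compound 2 in more than one place, so no single step is counted there.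

Compound 4 `CCCc1ccc(OCC(=O)Nc2cccc(C(=O)OC)c2)cc1` is not yet measured. It differs from compound 2 in one place: propyl in place of 1,1,3,3-tetramethylbutyl on an aromatic carbon. For the measured compounds named here, no measured step bears on this change. Going by the values given here, the 1,1,3,3-tetramethylbutyl is present in compounds 1, 2 and 3 alike, so the series gives no measured example of replacing it. Among the compounds with values here, the only step measured, a 3.3-fold lower number from compound 1 to compound 2 (0.51 log units; beyond the scatter), concerns the other ring and says nothing about this position.

With nothing to anchor the change, the expectation for compound 4 in this assay is a weaker inhibitor than compound 2, with a wide range, a step of a 3.4-fold higher number from compound 2 to compound 4 (0.53 log units; beyond the scatter). Compound 4 is therefore estimated at 30000 nM, between 8000 nM and 120000 nM.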

Compound 4, half-maximal inhibitory concentration: > 40000 nM
Compound 4: no number, only a limit; the forecaster's own chance of this, stated with the estimate: 25%; at least 1.3-fold (0.12 log units) between middle value and limit.
By their numbers in this assay, from the lowest: compound 3; then compound 2; then compound 1. At a limit, above all of these: compound 4.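

The 1,1,3,3-tetramethylbutyl, common to compounds 1, 2 and 3, now has a measured replacement: in this assay, propyl in its place gives an at least 4.4-fold higher number from compound 2 to compound 4 (0.65 log units; beyond the scatter). This position is therefore not indifferent to the group it carries: going from 8 heavy atoms to 3 heavy atoms, with no hydrogen-bond donors or acceptors on either side, weakens inhibition beyond the scatter. The result for compound 4 is a limit and not a number, so the step has a lower bound only: the limit of > 40000 nM in this assay, at which 1 of the 4 values shown sits.

Going by these compounds, how much further the true step extends remains open. So does whether a hexyl chain, a cyclohexyl ring or an amine on this aromatic carbon would keep inhibition nearer to that of compound 2.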